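Bridged amidinothiols: carboxy added to the ring core

The source may hold more compounds than are shown below. What is called first, only, known or untested is meant among the compounds shown, and "the series" means these compounds.

Compound 1 `N=C(CS)NCC1CCCCC1` carries a single saturated ring on the side chain; in a functional assay on the whole organism (stomach, strain beagle) for inhibition, with Canis familiaris (Canis lupus familiaris) as the target, with a stated time of 2 h, at a dose of 8 mg/kg (a lower number here means a weaker effect, a higher number a stronger effect of the compound at the dose given), compound 1 gives 86%. Compound 2 `N=C(CS)NCC12CCC(CC1)C2` replaces that ring with a bridged two-ring system, and in this assay compound 2 gives 91%. Compound 3 `N=C(CS)NCC12CCC(CC1)CC2` widens the bridged system by one ring carbon; in this assay compound 3 gives 87%. Compound 3 holds the second highest of the three numbers, with compound 1 nearest and compound 2 furthest, yet both gaps lie within the scatter, so the three compounds cannot be separated on these data.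

Compound 4 `N=C(CS)NCC12CCC(C(=O)O)(CC1)CC2` differs from compound 3 by carboxy in place of hydrogen on a saturated ring carbon. Within the data shown here, no measured pair shows a change of this kind, so the size of the step has no anchor among the measured compounds. The step of a number 17 percentage points lower from compound 3 to compound 4 (beyond the scatter) is expected to be downward and somewhat beyond the scatter. Compound 4 is estimated at 70%, with a range from 45% to 90%. Among the measured compounds shown here, the range is wide; none of the measured compounds carries a carboxy group.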

Compound 4, a percentage reported as inhibition, in the whole organism at one dose (the size of the read-out at that dose, not a potency): 0%
The estimate for compound 4 lay 70 percentage points above the measured number, outside the stated range (below it).
By their numbers in this assay, from the lowest: compound 4; then compounds 1, 3 and 2 (each within the scatter of the next).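

In this assay, carboxy in place of hydrogen on a saturated ring carbon gives a number 87 percentage points lower from compound 3 to compound 4 (beyond the scatter), a large step, so the read-out at this dose depends strongly on what this ring carbon carries. Compounds 1, 2 and 3 differ in the ring part of the side chain yet lie within the scatter of each other, and this is the first change shown that moves the read-out beyond it. No measurement at hand bears on why the read-out collapses here.

On these data alone, whether the loss belongs to the carboxylic acid itself stays open: a methyl ester, a primary amide or a hydroxymethyl group on the same ring carbon would tell. Also open, as far as these compounds go, is whether carboxy gives a step of this size on the core of compound 1 or compound 2.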